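The source may hold more compounds than are shown below. What is called first, only, known or untested is meant among the compounds shown, and "the series" means these compounds.

Measured so far in an assay on cells (Oocyte) for inhibition of pannexin-1 (Mus musculus), read by voltage clamp, tested at 50 uM, in the presence of a further agent that is not named here; on this read-out higher numbers stand for more inhibition at the one concentration tested (going by the name of the read-out) and lower numbers for less inhibition:
compound 1 `O=C(O)c1ccc(CNS(=O)(=O)c2ccc3c(c2)cc(C(=O)O)n3Cc2ccc(C(=O)O)cc2)cc1` gives 100%;
compound 2 `O=C(O)c1cn(CCCCc2ccccc2)c2ccc([N+](=O)[O-])cc12` gives 65.7%;
compound 3 `O=C(O)c1cn(Cc2ccccc2)c2ccc([N+](=O)[O-])cc12` gives 65%.

Compound 3 holds the lowest of the three numbers. Its nearest neighbour is compound 2, whose number lies within the usual scatter of it, so no order between these two can be read. Compound 1 stands well apart, its number beyond the scatter above that of compound 3; the two structures differ in many places at once, so only the two values themselves can be set side by side.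

Compound 4 `O=C(O)c1ccc(Cn2cc(C(=O)O)c3cc([N+](=O)[O-])ccc32)cc1` differs from compound 3 in one place: carboxy in place of hydrogen on an aromatic carbon. Within the data shown here, no step between measured compounds carries this change, so its direction has to be weighed from the values alone. Among the measured compounds shown here, compound 1, the only measured compound bearing carboxy on rings of this kind, gives 100% in this assay, which points, weakly, upward. The step from compound 3 to compound 4 is therefore expected to be a small rise, a number 10 percentage points higher from compound 3 to compound 4 (within the scatter), perhaps no larger than the scatter. Compound 4 is estimated at 75% in this assay, within 55% to 95%.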

Compound 4, a percentage reported as inhibition, at one concentration (the size of the read-out at that concentration, not a potency): 54%
The estimate for compound 4 lay 21 percentage points above the measured number; the whole stated range lies above it.
By their numbers in this assay, from the lowest: compound 4; then compounds 3 and 2 (each within the scatter of the next); then compound 1.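

Carboxy in place of hydrogen on an aromatic carbon, para to a large group, gives the first step that can be read in this assay: a number 11 percentage points lower from compound 3 to compound 4 (beyond the scatter). The change therefore moves the read-out downward at this position, although compound 4 still gives 54% and so keeps a substantial part of the inhibition at the one concentration tested. No available evidence bears on why the number falls with this change.

From the compounds shown here alone, whether the fall belongs to carboxy itself or would also follow from another group at the same place remains open, and a methyl ester, an amide or a hydroxy group there could separate these cases. Going by these compounds, it is equally open whether carboxy on the ring of the longer chain in compound 2 would give a step of the same direction and size.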